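Carboxy in Place of Hydroxymethyl: Expecting Compound 4

A few compounds are considered here, and "the series" means these few. Any claim that something is new, unique, unknown or untested is made for them only; others in the source may bear on it.

Compound 1, `C=CC(=O)Nc1ccc(Cn2nc(-c3ccc(Oc4ccccc4)cc3)cc2C(=O)O)cc1`: > 60000 nM
Compound 2, `O=C(CCl)Nc1ccc(Cn2nc(-c3ccc(Oc4ccccc4)cc3)cc2C(=O)O)cc1`: 1500 nM
Compound 3, `O=C(CCl)Nc1cccc(Cn2nc(-c3ccc(Oc4ccccc4)cc3)cc2CO)c1`: 400 nM

Of the compounds shown here, three sharing one core have been tested in a functional assay on Z-138 cells (Homo sapiens) for inhibition, read by luminescence and CellTiter-Glo, with a stated time of 72 h; a lower number here means a stronger inhibitor, a higher number a weaker inhibitor. Compound 1 gives > 60000 nM, which is the limit of > 60000 nM in this assay, at which 1 of the 3 values shown sits, and therefore a limit rather than a measured number. Among the compounds with values here, compound 2 gives 1500 nM, and the only single-point step among the measured compounds, an at least 40-fold lower number from compound 1 to compound 2 (1.60 log units; beyond the scatter), shows that this change alone moves the result far. Within the data shown here, compound 3 gives 400 nM, the lowest of the two numbers recorded; compound 2 stands nearest with a higher number, but compound 2 and compound 3 differ in more than one place, so no single step separates them.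

Compound 4, `O=C(CCl)Nc1cccc(Cn2nc(-c3ccc(Oc4ccccc4)cc3)cc2C(=O)O)c1`, has not yet been measured. It differs from compound 3 by carboxy in place of hydroxymethyl on an aromatic carbon. Among the measured compounds shown here, no measured step touches this part of the shared core: the one measured step concerns the group on the carbonyl carbon, so it does not bear directly on this change. With nothing in the data pointing either way, the change is expected to be small, giving an estimated step of a 1.5-fold higher number from compound 3 to compound 4 (0.18 log units; within the scatter) that need not go beyond the scatter. Compound 4 is therefore expected to give about 600 nM, with a likely range from 200 nM to 2500 nM.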

Compound 4, half-maximal inhibitory concentration: 9100 nM
Compound 4: middle estimate off by 15-fold (1.18 log units), on the low side, and the stated range ends below it.
By their numbers in this assay, from the lowest: compound 3; then compound 2; then compound 4. At a limit, above all of these: compound 1.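

In this assay, within the data shown here, the group on the aromatic carbon next to the ring nitrogen proves to matter a great deal, a point no earlier step could address: with carboxy in place of hydroxymethyl, the result is a 23-fold higher number from compound 3 to compound 4 (1.36 log units; beyond the scatter). With carboxy kept at that place, 3-(((chloromethyl)carbonyl)amino)phenyl in place of 4-(((chloromethyl)carbonyl)amino)phenyl gives a 6.1-fold higher number from compound 2 to compound 4 (0.78 log units; beyond the scatter), while the same 3-substituted group in place of 4-((vinylcarbonyl)amino)phenyl gives an at least 6.5-fold lower number from compound 1 to compound 4 (0.81 log units; beyond the scatter). The value of compound 1 is a limit rather than a measured number, so the last step fixes only a minimum size: the limit of > 60000 nM in this assay, at which 1 of the 4 values shown sits.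

The compounds shown do not pair hydroxymethyl with 4-(((chloromethyl)carbonyl)amino)phenyl, so it remains open whether the carboxy step would be as large with that group in place. Also open, going by these compounds, is how this place would respond to other groups, such as a methyl ester, a primary amide or an aminomethyl group, which could show whether the large step is specific to carboxy.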